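A dinitrophenyl group where dialkylphenyl gave only a limit

The source may report more compounds than this note shows. Statements on the series, on what has been measured and on what is new or still open speak of the compounds shown alone.

Compound 3 `CCc1cccc(C)c1-n1nncc1CN1C(=O)C2(C(C#N)=C(N)Oc3c(N)cc4nc5ccccc5nc4c32)c2ccccc21` carries a 2-ethyl-6-methylphenyl group on an aromatic nitrogen of the shared core. In a functional assay on A549 cells (Homo sapiens) for antiproliferative activity, read by MTT assay, with a stated time of 48 h (a lower number here means a stronger inhibitor, a higher number a weaker inhibitor), compound 3 gives > 50000 nM, which is a limit of the assay and not a number. Compound 1 `N#CC1=C(N)Oc2c(N)cc3nc4ccccc4nc3c2C12C(=O)N(Cc1cnnn1-c1cccc(Br)c1)c1ccccc12`, with 3-bromophenyl at that place, is the only one of the three with a true number: in this assay compound 1 gives 18900 nM. Compound 2 `CC(=O)Nc1ccc(-n2nncc2CN2C(=O)C3(C(C#N)=C(N)Oc4c(N)cc5nc6ccccc6nc5c43)c3ccccc32)cc1` carries 4-acetamidophenyl there. In this assay compound 2 gives > 50000 nM, again a limit of the assay. For the measured compounds named here, two measured steps bear on the change: an at least 2.6-fold higher number from compound 1 to compound 2 (0.42 log units; beyond the scatter) and an at least 2.6-fold higher number from compound 1 to compound 3 (0.42 log units; beyond the scatter). There is a step that the two limits leave unreadable from compound 2 to compound 3, because both ends sit at the limit of > 50000 nM in this assay, at which 2 of the 3 values shown sit. Compound 4 `N#CC1=C(N)Oc2c(N)cc3nc4ccccc4nc3c2C12C(=O)N(Cc1cnnn1-c1ccc([N+](=O)[O-])cc1[N+](=O)[O-])c1ccccc12` differs from compound 3 by 2,4-dinitrophenyl in place of 2-ethyl-6-methylphenyl on an aromatic nitrogen. Both aryl groups tried in place of 3-bromophenyl gave only limits, so another weak result is expected. For compound 4 the expected step is an at least 1.2-fold lower number from compound 3 to compound 4 (0.09 log units; that floor lies within the scatter). Compound 4 is therefore expected to give 40000 nM in this assay, with a range from 12000 nM to 150000 nM, and a fair chance that only a limit is reported.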

Compound 4, half-maximal inhibitory concentration: > 50000 nM
Compound 4 ended at the assay's limit; the forecaster's own chance of this, stated with the estimate: 55%; at least 1.2-fold (0.09 log units) between middle value and limit.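

The new step is an at least 2.6-fold higher number from compound 1 to compound 4 (0.42 log units; beyond the scatter), so a third replacement for 3-bromophenyl on this aromatic nitrogen also fails to match compound 1. The replacements now carry quite different substituents (two alkyl groups, an acetamide and two nitro groups), yet in this assay only compound 1 gives a true number, 18900 nM. The steps among compound 2, compound 3 and compound 4 cannot be read, because both ends of each sit at the same limit: the limit of > 50000 nM in this assay, at which 3 of the 4 values shown sit.

The compounds shown leave open whether the bromine itself matters, a question that an unsubstituted phenyl group, or chlorine in place of the bromine, would address. As far as these compounds go, how far compound 2, compound 3 and compound 4 differ from one another also stays open.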